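Swapping methoxy for acetamido in compound 2

A few compounds are considered here, and "the series" means these few. Any claim that something is new, unique, unknown or untested is made for them only; others in the source may bear on it.

Measured so far in a functional assay on HeLa cells (Homo sapiens) for cytotoxicity, read by sulforhodamine B assay, with a stated time of 3 days (a higher number here means a weaker inhibitor, a lower number a stronger inhibitor), are these compounds:
compound 1 `COc1ccc(CNc2c(-c3ccccc3O)nc3ccccn23)cc1` gives 15 nM
compound 2 `COc1ccc(CNc2c(-c3ccccc3OC)nc3ccccn23)cc1` gives 230 nM
compound 3 `COc1ccc(CNc2c(-c3cc(Cl)cc(Cl)c3O)nc3ccccn23)cc1` gives 4160 nM

Compound 2 has the second highest of these three numbers, with compound 1 lower and compound 3 higher. Compound 4 `COc1ccc(CNc2c(-c3ccccc3NC(C)=O)nc3ccccn23)cc1` differs from compound 2 in one group acetamido in place of methoxy on an aromatic carbon with acetamido in place of methoxy on an aromatic carbon, ortho to a large group. Going by the values given here, no measured step makes this exact swap. The closest evidence comes from changes on the same ring, and each was large: a 15-fold higher number from compound 1 to compound 2 (1.19 log units; beyond the scatter) with methyl in place of hydrogen on the oxygen, and a 280-fold higher number from compound 1 to compound 3 (2.44 log units; beyond the scatter) with 3,5-dichloro-2-hydroxyphenyl in place of 2-hydroxyphenyl. Compound 1 and compound 3 both carry a hydroxy group yet lie far apart, so the presence of a hydrogen-bond donor alone is a poor guide. Both changes from compound 1 raised the number, so a further rise seems likelier than a fall. In this assay the expected step is a 3.0-fold higher number from compound 2 to compound 4 (0.48 log units; beyond the scatter) toward a higher number, though this estimate is uncertain. The estimated value for compound 4 is 700 nM (expected range 120 nM to 4000 nM).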

Compound 4, half-maximal inhibitory concentration: > 10000 nM
Compound 4 ended at the assay's limit; the forecaster's own chance of this, stated with the estimate: 5%; middle value at least 14-fold (1.15 log units) away from the limit.
By their numbers in this assay, from the lowest: compound 1; then compound 2; then compound 3. At a limit, above all of these: compound 4.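

In this assay, compound 4 stands at a limit of the assay and not at a measured number: the limit of > 10000 nM in this assay, at which 1 of the 4 values shown sits. Even read as a limit, the change of methoxy to acetamido on this aromatic carbon, ortho to a large group, gives an at least 43-fold higher number from compound 2 to compound 4 (1.63 log units; beyond the scatter), and the change of hydroxy to acetamido at the same place gives an at least 660-fold higher number from compound 1 to compound 4 (2.82 log units; beyond the scatter). Compound 1 and compound 4 each carry a hydrogen-bond donor at this place, yet they sit at opposite ends of the series, so this place responds strongly to which group it holds, and having a donor there does not by itself keep the number low.

The compounds shown leave open how a plain amine at this place would compare with hydroxy and acetamido. They also leave open whether an ethoxy group would fall nearer to methoxy or to acetamido.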